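The source may hold more compounds than are shown below. What is called first, only, known or untested is meant among the compounds shown, and "the series" means these compounds.

Compound 1 `CC(=O)OCCOn1cnc2c(Cl)nc(N)nc21`: in a functional assay on L1210 cells (Mus musculus) for inhibition (on this read-out higher numbers stand for weaker inhibition and lower numbers for stronger inhibition), compound 1 gives > 500000 nM, which is a limit of the assay and not a number.
Compound 2 `CC(=O)OCCOn1cnc2c(Cl)nc(I)nc21`: compound 2 gives 8600 nM.
Compound 3 `COc1nc(I)nc2c1ncn2OCCO`: compound 3 gives > 500000 nM, again a limit of the assay and not a number.
Compound 4 `CC(=O)OCCOn1cnc2c(S)nc(N)nc21`: not yet measured.

Compound 1 stands at the limit of > 500000 nM in this assay, at which 2 of the 3 values shown sit, so no number is known for it, only the limit. Among the measured compounds shown here, the only measured single change is an at least 58-fold lower number from compound 1 to compound 2 (1.76 log units; beyond the scatter), a large move away from the limit toward stronger inhibition when the amino group is exchanged. Compound 4 keeps the amino group and instead carries sulfanyl in place of chloro on an aromatic carbon. For the measured compounds named here, no measured step tells what this exchange does, and the two compounds that keep the amino group, compound 1 and compound 3, both sit at the limit. On that basis the step from compound 1 to compound 4 is expected to be a number no higher from compound 1 to compound 4 (the limit leaves the size open), that is, none beyond the scatter, with a good chance that only a limit is reported again. Compound 4 is therefore estimated at 500000 nM, with a range from 100000 nM to 2000000 nM.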

Compound 4, half-maximal inhibitory concentration: 3200 nM
For compound 4 the middle estimate is 160-fold (2.19 log units) above the measured one; measured number outside the range, below it.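

The amino group does not by itself hold this series at the limit: with it kept in place, exchanging only the chloro for sulfanyl on the aromatic carbon gives an at least 150-fold lower number from compound 1 to compound 4 (2.19 log units; beyond the scatter). Among the compounds shown here, this is the first sign that the carbon carrying the chloro also matters strongly for inhibition in this assay, as until now only the exchange of the amino group had moved a compound away from the limit. The true size of this step stays unknown, since compound 1 gives only a limit and not a number: the limit of > 500000 nM in this assay, at which 2 of the 4 values shown sit.

The compounds shown leave open whether sulfanyl is special at this carbon, or whether a methylthio group, a hydroxyl or an amine there would serve as well. They also leave open what sulfanyl would do with iodo in place of the amino group on the same core.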